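Replacing isopropylcarbonyl with oxetan-3-yl on compound 1

The source may hold more compounds than are shown below. What is called first, only, known or untested is meant among the compounds shown, and "the series" means these compounds.

Measured in a functional assay on NCI-H2228 cells (Homo sapiens) for inhibition, read by CellTiter-Glo, with a stated time of 96 h; a higher number here means a weaker inhibitor, a lower number a stronger inhibitor:
- Compound 1 `Cc1cc(Nc2ncc(Cl)c(Nc3cn(C)nc3S(=O)(=O)C(C)C)n2)c(OC2CC2)cc1C(=O)C(C)C`: 149 nM
- Compound 2 `Cc1cc(Nc2ncc(Cl)c(Nc3cn(C)nc3S(=O)(=O)C(C)C)n2)c(C(F)(F)F)cc1C1CCN(C)CC1`: 1080 nM
- Compound 3 `Cc1cc(Nc2ncc(Cl)c(Nc3cn(C)nc3S(=O)(=O)C(C)C)n2)c(OC(C)C)cc1C1CCNC1`: 364 nM

Compound 1 has the lowest number of the three, and its gaps to compound 3 and compound 2 both lie beyond the scatter. Compound 4 `Cc1cc(Nc2ncc(Cl)c(Nc3cn(C)nc3S(=O)(=O)C(C)C)n2)c(OC2CC2)cc1C1COC1`, not yet measured, carries oxetan-3-yl in place of isopropylcarbonyl on an aromatic carbon. Among the measured compounds shown here, no pair of measured compounds differs in one place only, so nothing isolates this change. For the measured compounds named here, with compound 1 at 149 nM as the lowest number so far, a small move upward in this assay is expected rather than a gain. The expected size is a 1.9-fold higher number from compound 1 to compound 4 (0.27 log units; within the scatter), about the edge of the scatter. For compound 4 the estimated value is 280 nM, with an expected range of 90 nM to 850 nM.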

Compound 4, half-maximal inhibitory concentration: 44 nM
Beside the measured number, compound 4's estimate is 6.4-fold (0.80 log units) above it; measured number below the stated range.
By their numbers in this assay, from the lowest: compound 4; then compound 1; then compound 3; then compound 2.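

In this assay, among the compounds shown here, the aromatic carbon ortho to a methyl group and para to a large group gives the first single-place comparison in this set: replacing isopropylcarbonyl with oxetan-3-yl produces a 3.4-fold lower number from compound 1 to compound 4 (0.53 log units; beyond the scatter) and so improves on the best earlier compound. The open-chain ketone is therefore not needed for activity on this core, and a four-membered non-aromatic ring is accepted at this carbon. Nothing measured here explains the gain. From the compounds shown here alone, it remains open whether the ring oxygen matters, which a cyclobutyl group at this carbon would test, and whether a larger tetrahydropyranyl ring would behave the same way.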